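This account rests on a few compounds, and the source may have more. Where it says the series, first, only, none or still open, it means among the compounds named here.

Measured so far in a physicochemical assay for solubility, read by nephelometry; a lower number here means a less soluble compound, a higher number a more soluble compound:
- compound 1 `CC1(C)C(=O)N(c2ccc(SC(F)(F)F)cc2)C(=O)N1Cc1ccncc1`: < 0.02 ug/mL
- compound 2 `CC1(C)C(=O)N(c2ccc(SC(F)(F)F)cc2)C(=O)N1Cc1ccnc(N2CCCCC2)c1`: < 0.024 ug/mL

Compound 2 gives < 0.024 ug/mL, which is a limit of the assay and not a number. Compound 1 gives < 0.02 ug/mL, which is also a limit. Neither compound therefore has a readable position in this assay, and the two cannot be ranked.

Compound 3 `CC1(C)C(=O)N(c2ccc(SC(F)(F)F)cc2)C(=O)N1Cc1ccnc(N2CCNCC2)c1` is the next to be read. The change is piperazin-1-yl in place of piperidin-1-yl on an aromatic carbon, on an aromatic carbon of a six-membered aromatic ring with 1 nitrogen, next to the ring nitrogen. Among the compounds with values here, the only measured step that bears on it is a step that the two limits leave unreadable from compound 1 to compound 2, which also concerns piperidin-1-yl on an aromatic carbon. That step offers no size to carry over, so the expectation rests on the structural change alone and remains loose.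

An upward move in this assay is expected, with the estimated step being an at least 4.1-fold higher number from compound 2 to compound 3 (0.61 log units; beyond the scatter), and another limit remains quite possible. The estimate for compound 3 is 0.1 ug/mL, with an expected range from 0.02 ug/mL to 2 ug/mL.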

Compound 3, solubility: < 0.024 ug/mL
Compound 3: only a limit was reported (the forecaster's own chance of this, stated with the estimate: 40%); at least 4.1-fold (0.61 log units) between middle value and limit.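

In this assay compound 3 gives < 0.024 ug/mL, which is a limit of the assay and not a number. With compound 1 and compound 2 also reported only as limits, no step among these three compounds can be read. The compounds shown leave open the direction and size of any of these changes in this assay.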